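The source may hold more compounds than are shown below. What is called first, only, known or untested is meant among the compounds shown, and "the series" means these compounds.

Compound 1 `COc1ccc(NS(=O)(=O)c2cc(Cl)cc(Cl)c2)cc1N1CCN(C)CC1` gives 2 nM in an assay on HeLa cells for binding affinity to 5-hydroxytryptamine receptor 6 (Homo sapiens); on this read-out higher numbers stand for weaker inhibition and lower numbers for stronger inhibition.
Compound 2 `COc1ccc(NS(=O)(=O)c2cccc(C#N)c2)cc1N1CCN(C)CC1` gives 63.1 nM in this assay.
Compound 3 `COc1ccc(NS(=O)(=O)c2c(C)sc3ccc(Cl)cc23)cc1N1CCN(C)CC1` gives 1.26 nM in this assay.

Compound 2 has the highest number of the three; compound 1 sits well below it, and compound 3 lower still. The change to compound 4 `COc1ccc(NS(=O)(=O)c2ccc(Br)cc2)cc1N1CCN(C)CC1` is 4-bromophenyl in place of 3-cyanophenyl on a sulfonyl sulfur. Among the measured compounds shown here, the one measured step that bears on it is a 32-fold higher number from compound 1 to compound 2 (1.50 log units; beyond the scatter), where the 3-cyanophenyl in place of the 3,5-dichlorophenyl raised the number by a large amount. Going back from the nitrile to a halogen-bearing phenyl, the number for compound 4 is expected to fall, though a single bromine need not reach as far as compound 1. The estimate for compound 4 in this assay is 10 nM, within 3 nM to 40 nM, an expected step of a 6.3-fold lower number from compound 2 to compound 4 (0.80 log units; beyond the scatter).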

Compound 4, inhibition constant: 5.01 nM
For compound 4 the middle estimate is 2.0-fold (0.30 log units) above the measured one; measured number inside the range.
By their numbers in this assay, from the lowest: compounds 3 and 1 (each within the scatter of the next); then compound 4; then compound 2.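

In this assay, the 4-bromophenyl on the sulfonyl sulfur lies far closer to the 3,5-dichlorophenyl of compound 1 than to the 3-cyanophenyl: the step from the nitrile is large (a 13-fold lower number from compound 2 to compound 4 (1.10 log units; beyond the scatter)), while the remaining gap is modest but still beyond the scatter (a 2.5-fold higher number from compound 1 to compound 4 (0.40 log units; beyond the scatter)). Thus, a single bromine on the phenyl ring is enough to recover most of the difference seen with the 3-cyanophenyl. No measurement shown accounts for either step.

The 4-bromophenyl and 3,5-dichlorophenyl differ in both halogen and substitution, so their separate contributions remain unresolved. A 4-chlorophenyl or 3-bromophenyl group could separate the two.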